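A Bromophenyl Amide Weighed Against an Inactive Dimethoxy Analogue

The compounds below may be only part of what the source reports. "The series", "measured", "known", "first", "only" and "open" are said of these compounds alone.

The series shares one core, carried by compound 1 `O=C(CN1CCN(c2nnc(Cc3ccncc3)c3ccccc23)CC1)Nc1ccc(F)c(Cl)c1`, compound 2 `COc1ccc(NC(=O)CN2CCN(c3nnc(Cc4ccccc4)c4ccccc34)CC2)cc1OC` and compound 3 `O=C(CN1CCN(c2nnc(Cc3ccccc3)c3ccccc23)CC1)Nc1ccc(Br)cc1`, and differs mainly in the aryl group on the amide nitrogen. In a functional assay on A549 cells (Homo sapiens) for cytotoxicity, read by MTT assay, with a stated time of 72 h (on this read-out higher numbers stand for weaker inhibition and lower numbers for stronger inhibition), compound 1 gives 12300 nM. In this assay compound 3 gives 2000 nM. Compound 2 stands apart: in this assay compound 2 is reported as "not active" (no number reported), and no single number accompanies that outcome, so its place on the scale cannot be fixed more closely than that it lies outside the range where the others were measured.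

Compound 4 `O=C(CN1CCN(c2nnc(Cc3ccccc3)c3ccccc23)CC1)Nc1cccc(Br)c1` has not yet been measured. The change from compound 2 to compound 4 is 3-bromophenyl in place of 3,4-dimethoxyphenyl on an amide-type nitrogen. Among the measured compounds shown here, no measured pair in the set traces this exact change, so no step size can be quoted for it. The expectation still leans one way: compound 3 carries a bromophenyl group on the same nitrogen and gives 2000 nM in this assay, whereas the dimethoxy compound 2 gave no number at all, so the move toward a bromophenyl group is expected to bring compound 4 into the measurable range, a shift toward stronger inhibition that should exceed the usual scatter. Compound 4 is estimated at 4000 nM in this assay, within a range of 1000 nM to 20000 nM.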

Compound 4, half-maximal inhibitory concentration: "not active" (no number reported)
The entry for compound 4 holds no number; there is nothing to compare the estimate with.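

In this assay compound 2 and compound 4 are both reported as "not active" with no number, so no step can be read between them. No evidence bears on this outcome. The compounds shown leave open how far compound 4 lies from compound 3, since only compound 3 carries a number on this scale.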